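The source may report more compounds than this note shows. Statements on the series, on what has been measured and on what is new or still open speak of the compounds shown alone.

In a functional assay on PANC-1 cells (Homo sapiens) for inhibition, read by sulforhodamine B assay, with a stated time of 48 h (a higher number here means a weaker inhibitor of growth, a lower number a stronger inhibitor of growth), compound 1 (`O=C(O)c1cn(C2CC2)c2cc(N3CCN(C(=O)CCSc4nnnn4-c4ccc(Br)cc4)CC3)c(F)cc2c1=O`) gives 60 nM and compound 2 (`CCn1cc(C(=O)O)c(=O)c2cnc(N3CCN(C(=O)CCSc4nnnn4-c4ccc(Br)cc4)CC3)nc21`) gives 60 nM as well, so the two stand level on these numbers. Compound 3 (`O=C(O)c1cn(C2CC2)c2cc(N3CCN(C(=O)CCSc4nnnn4Cc4ccccc4)CC3)c(F)cc2c1=O`) has not yet been tested. It keeps the core of compound 1 and carries benzyl in place of 4-bromophenyl on an aromatic nitrogen. Both measured compounds carry the 4-bromophenyl group. Among the measured compounds shown here, no measured pair shows what this swap does, so any forecast here is loose. A modest loss of growth inhibition seems the more likely outcome, although a result within the scatter would be no surprise. The expected move is a 2.5-fold higher number from compound 1 to compound 3 (0.40 log units; beyond the scatter) in the weaker direction, and this is only an estimate. For compound 3 the estimated value is 150 nM with a range from 40 nM to 600 nM around it.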

Compound 3, concentration for 50% growth inhibition: 60 nM
The estimate for compound 3 lay 2.5-fold (0.40 log units) above the measured number, within the range that was stated.
By their numbers in this assay, from the lowest: compounds 1, 2 and 3 (each within the scatter of the next).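

In this assay, among the compounds shown here, the 1-(4-bromophenyl)-1H-tetrazol-5-yl to 1-benzyl-1H-tetrazol-5-yl swap gives no change at the digits printed from compound 1 to compound 3 (within the scatter) and so offers the first direct reading at this position. For this pair, neither the bromine nor direct attachment of the six-membered aromatic ring to the aromatic nitrogen is needed to keep growth inhibition at this level, since benzyl serves as well as 4-bromophenyl on the core of compound 1. No measurement shown gives a reason for this outcome.

As far as these compounds go, whether the same swap would read the same way on the core of compound 2 remains open. Also open, from the compounds shown here alone, is how far this nitrogen accepts other groups, such as a small methyl group, a longer chain ending in phenyl, or a benzyl carrying an amine or a carboxylic acid.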